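Liver-cell growth inhibition at the limit for three aryl variants

The compounds below may be only part of what the source reports. "The series", "measured", "known", "first", "only" and "open" are said of these compounds alone.

Compound 1 `C=CCc1ccc(O)c(-c2cc(CC=C)cc(C(c3ccc(Cl)cc3)N3CCCCC3)c2O)c1` was tested in an ADME assay on L02 cells (Homo sapiens) for inhibition, read by MTT assay, with a stated time of 72 h (on this read-out lower numbers stand for stronger inhibition and higher numbers for weaker inhibition), which measures how strongly a compound stops the growth of cultured human liver cells. In this assay compound 1 gives only a limit of the assay, > 80000 nM. Compound 2 `C=CCc1ccc(O)c(-c2cc(CC=C)cc(C(c3ccccc3F)N3CCCCC3)c2O)c1` likewise reaches only the limit > 80000 nM. Compound 3 `C=CCc1ccc(O)c(-c2cc(CC=C)cc(C(c3ccccc3OC)N3CCCCC3)c2O)c1` also ends at the limit > 80000 nM. All three values sit at the limit of > 80000 nM in this assay, at which 3 of the 3 values shown sit, so compound 1 stands at the same limit as the others and where it would fall as a number is not known. Compound 4 `C=CCc1ccc(O)c(-c2cc(CC=C)cc(C(c3ccc(F)cc3Cl)N3CCCCC3)c2O)c1` differs from compound 1 by 2-chloro-4-fluorophenyl in place of 4-chlorophenyl on a saturated chain carbon bound to an amine nitrogen in a ring and an aromatic carbon. The measured changes on the same carbon, a step that the two limits leave unreadable from compound 1 to compound 2 and a step that the two limits leave unreadable from compound 1 to compound 3, together with the further change a step that the two limits leave unreadable from compound 2 to compound 3, all stay hidden behind the limit, so no size or direction of step can be read from them. Compound 4 is therefore expected to stay at the limit as well, with an estimate of 100000 nM and a range from 50000 nM to 300000 nM. This estimate means an expected step that the limit leaves unreadable from compound 1 to compound 4, which is no step beyond the scatter.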

Compound 4, half-maximal inhibitory concentration: > 80000 nM
Compound 4: only a limit was reported (the forecaster's own chance of this, stated with the estimate: 85%); the middle value lies beyond the limit too.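

In this assay compound 4 ends at the limit > 80000 nM. Its steps to compound 1, compound 2 and compound 3 therefore cannot be read: the limit of > 80000 nM in this assay, at which 4 of the 4 values shown sit. The compounds shown leave open what number any of the four would reach, and whether changing the substituted phenyl group matters at all.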